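The source may hold more compounds than are shown below. What is called first, only, known or untested is meant among the compounds shown, and "the series" means these compounds.

Compound 1 `Cc1ccc(NC(=O)C2CCN(C/C=C/c3ccccc3)CC2)cc1`: 29600 nM
Compound 2 `CCc1ccc(NC(=O)C2CCN(C/C=C/c3ccccc3)CC2)cc1`: 19600 nM
Compound 3 `CCCCc1ccc(NC(=O)C2CCN(C/C=C/c3ccccc3)CC2)cc1`: 5910 nM

All three values come from a functional assay on A549 cells (Homo sapiens) for inhibition, read by MTT assay, with a stated time of 72 h; on this read-out higher numbers stand for weaker inhibition and lower numbers for stronger inhibition. Compound 3 has the lowest number of the three, which makes it the strongest inhibitor so far. The next case is compound 4 `COc1ccc(NC(=O)C2CCN(C/C=C/c3ccccc3)CC2)cc1`, and the change is methoxy in place of butyl on an aromatic carbon. For the measured compounds named here, no measured compound carries a methoxy, so only the chain steps offer guidance. The first, a 1.5-fold lower number from compound 1 to compound 2 (0.18 log units; within the scatter), is small. The others are a 3.3-fold lower number from compound 2 to compound 3 (0.52 log units; beyond the scatter) and a 5.0-fold lower number from compound 1 to compound 3 (0.70 log units; beyond the scatter). Among these three compounds, then, the longer chain goes with the lower number, and the butyl of compound 3 stands out. Methoxy removes that butyl and puts a much shorter group in its place, closer to the ethyl of compound 2 at 19600 nM. What the added oxygen does cannot be read from these data, so the uncertainty is wide. A modest rise in the number is expected, roughly reversing the gain seen with butyl, and the estimate means a 4.1-fold higher number from compound 3 to compound 4 (0.61 log units; beyond the scatter). For compound 4 the estimated value is 24000 nM, with an expected range of 10000 nM to 55000 nM.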

Compound 4, half-maximal inhibitory concentration: 83800 nM
Compound 4: middle estimate off by 3.5-fold (0.54 log units), on the low side; the measured number lies above the stated range.
By their numbers in this assay, from the lowest: compound 3; then compounds 2 and 1 (each within the scatter of the next); then compound 4.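

In this assay, methoxy on this aromatic carbon gives a higher number than every carbon chain tested, not only butyl (a 14-fold higher number from compound 3 to compound 4 (1.15 log units; beyond the scatter); a 4.3-fold higher number from compound 2 to compound 4 (0.63 log units; beyond the scatter); a 2.8-fold higher number from compound 1 to compound 4 (0.45 log units; beyond the scatter)). Compound 4 is therefore the weakest inhibitor of the four, and the link between a longer chain and a lower number among compounds 1 to 3 does not carry over to this oxygen-bearing group, which does not simply sit where its small size might place it among the chains. Nothing measured here explains why methoxy stands apart.

Still open, on these data alone, is whether butoxy, a longer chain attached through oxygen, would lower the number as butyl does or stay high like methoxy. As far as these compounds go, how a hexyl chain, a hydroxyl or an amine would behave at this carbon also remains unknown.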